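This account rests on a few compounds, and the source may have more. Where it says the series, first, only, none or still open, it means among the compounds named here.

Measured in a functional assay on DU-145 cells (Homo sapiens) for cytotoxicity, read by ELISA, with a stated time of 2 days; a lower number here means a stronger inhibitor, a higher number a weaker inhibitor:
- compound 1 `Oc1cccc(-c2cc(-c3ccccc3)nc(-c3ccccc3)c2)c1`: 17900 nM
- compound 2 `Oc1cccc(-c2cc(-c3ccccc3)nc(-c3cccnc3)c2)c1`: 18900 nM
- compound 3 `Oc1cccc(-c2cc(-c3ccccc3)nc(-c3ccncc3)c2)c1`: 18100 nM

Compound 3 stands level with the other two in this assay, with a 1.0-fold higher number from compound 1 to compound 3 (0.00 log units; within the scatter) and a 1.0-fold lower number from compound 2 to compound 3 (0.02 log units; within the scatter). The remaining measured step is a 1.1-fold higher number from compound 1 to compound 2 (0.02 log units; within the scatter). All three are aryl exchanges at one place on the shared core, and none reaches beyond the scatter.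

Compound 4 `Oc1ccc(-c2cc(-c3ccccc3)nc(-c3ccncc3)c2)cc1` differs elsewhere: 4-hydroxyphenyl in place of 3-hydroxyphenyl on an aromatic carbon. This is 4-hydroxyphenyl in place of 3-hydroxyphenyl on an aromatic carbon, opposite the ring nitrogen. Within the data shown here, no measured step touches this place, so the flat aryl exchanges bear on it only indirectly, and the series offers no direct reading of the change. With nothing pointing in either direction, no shift beyond the scatter is expected, though uncertainty remains wide. The expected step is a 1.1-fold lower number from compound 3 to compound 4 (0.03 log units; within the scatter). Compound 4 is estimated at 17000 nM, with an expected range of 6500 nM to 40000 nM.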

Compound 4, half-maximal inhibitory concentration: 2200 nM
For compound 4 the middle estimate is 7.7-fold (0.89 log units) above the measured one; measured number outside the range, below it.
By their numbers in this assay, from the lowest: compound 4; then compounds 1, 3 and 2 (each within the scatter of the next).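

In this assay, the place opposite the ring nitrogen responds to a change, whereas the aryl exchanges at the other place on the shared core stayed within the scatter: 4-hydroxyphenyl in place of 3-hydroxyphenyl gives an 8.2-fold lower number from compound 3 to compound 4 (0.92 log units; beyond the scatter). The two groups have the same atoms, joined differently, so a change in where the hydroxyl sits on this ring is enough to move the number beyond the scatter. Nothing available bears on the reason for this step.

Compound 4 alone carries 4-hydroxyphenyl, which leaves open whether the step would recur with phenyl or pyridin-3-yl in place of its pyridin-4-yl group. Also open, as far as these compounds go, is how far the hydroxyl itself matters, for which a methoxy group, an amine or a carboxylic acid in its place would be informative.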